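Removing a methyl group from an inactive hydrazone

This account rests on a few compounds, and the source may have more. Where it says the series, first, only, none or still open, it means among the compounds named here.

The compounds here share one core, a fused two-ring system carrying a carbonyl and a ring nitrogen with its hydrogen, from which a side arm extends through a double bond to nitrogen. Compound 1 `CCCC/N=C/c1cc2cc(C)ccc2[nH]c1=O` ends that arm in a butyl chain; in a functional assay, read by spectrophotometry, with a stated time of 30 min (a lower number here means a stronger inhibitor, a higher number a weaker inhibitor), compound 1 gives 63200 nM. Compound 2 `Cc1ccc2[nH]c(=O)c(/C=N/Nc3ccc([N+](=O)[O-])cc3)cc2c1` carries instead an aryl hydrazone bearing one nitro group, and in this assay compound 2 gives 109000 nM. These two values lie within the usual scatter of each other, so neither can be called the stronger. Compound 3 `Cc1ccc2[nH]c(=O)c(/C=N/Nc3ccc([N+](=O)[O-])cc3[N+](=O)[O-])cc2c1` adds a second nitro group to the aryl ring; in this assay compound 3 was reported only as "not active" (no number reported), with no number attached, so it stands outside the measured range rather than at a particular point on it.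

Compound 4 `O=c1[nH]c2ccccc2cc1/C=N/Nc1ccc([N+](=O)[O-])cc1[N+](=O)[O-]` differs from compound 3 in a single spot on the core: hydrogen in place of methyl on an aromatic carbon. Whether a lost methyl on the core shifts this assay cannot be judged from any measured pair here, since compounds 1 to 3 all keep it. The one known data point is that compound 3 showed no measurable inhibition, and the closest numbered neighbour, compound 2, sits at the weak end. The step is therefore expected to stay within the scatter, with compound 4 most likely remaining very weak or inactive. Compound 4 is estimated in this assay at 150000 nM, with a range from 50000 nM to 500000 nM.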

Compound 4, half-maximal inhibitory concentration: 190000 nM
Compound 4: the middle estimate sits 1.3-fold (0.10 log units) below what was measured; measured number inside the range.
By their numbers in this assay, from the lowest: compounds 1, 2 and 4 (each within the scatter of the next, the first and the last beyond it).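

In this assay compound 3 has only the report "not active", while compound 4 gives 190000 nM, so no step can be read between compound 3 and compound 4. The compounds shown leave open whether swapping methyl for hydrogen on the core changes inhibition at all. Nothing measured here explains these results.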